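Swapping the Aryl Group on a Sulfonamide Nitrogen

The source may report more compounds than this note shows. Statements on the series, on what has been measured and on what is new or still open speak of the compounds shown alone.

In a functional assay on cells (leukaemia cell line, Homo sapiens) for inhibition, read by sulforhodamine B assay, with a stated time of 48 h (on this read-out lower numbers stand for stronger inhibition of growth and higher numbers for weaker inhibition of growth), compound 1 `O=S(=O)(Nc1cccc(Cl)c1)c1ccc(-c2cnc(C3CC3)o2)cc1` gives 477 nM and compound 2 `Cc1ccc(NS(=O)(=O)c2ccc(-c3cnc(C4CC4)o3)cc2)cc1C` gives 420 nM on the same shared core. The measured gap is a 1.1-fold lower number from compound 1 to compound 2 (0.06 log units; within the scatter) and so no order is drawn between them. Compound 3 `O=S(=O)(Nc1cc(F)cc(Cl)c1)c1ccc(-c2cnc(C3CC3)o2)cc1` gives 1440 nM as the highest of the three numbers. The steps leading to it are a 3.0-fold higher number from compound 1 to compound 3 (0.48 log units; beyond the scatter) and a 3.4-fold higher number from compound 2 to compound 3 (0.54 log units; beyond the scatter) and both are modest.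

Compound 4 `Cc1cc(Cl)ccc1NS(=O)(=O)c1ccc(-c2cnc(C3CC3)o2)cc1` has not yet been measured. It carries 4-chloro-2-methylphenyl in place of 3-chloro-5-fluorophenyl on a sulfonamide nitrogen and so loses the fluoro group. Going by the values given here, no measured step makes this exact exchange, and the effect of its particular chloro and methyl pattern is untested. The closest evidence is that compound 1 and compound 2, which also lack fluoro, sit a modest step lower than compound 3. A partial return towards their numbers is therefore expected, though with wide uncertainty. The expected step in this assay is a 2.4-fold lower number from compound 3 to compound 4 (0.38 log units; beyond the scatter) in the direction of stronger inhibition of growth. Compound 4 is estimated at 600 nM within an expected range of 220 nM to 1600 nM once measured.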

Compound 4, concentration for 50% growth inhibition: 277 nM
For compound 4 the middle estimate is 2.2-fold (0.34 log units) above the measured one; low and high end bracket the measured number.
By their numbers in this assay, from the lowest: compounds 4, 2 and 1 (each within the scatter of the next); then compound 3.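

In this assay, putting 4-chloro-2-methylphenyl in place of 3-chloro-5-fluorophenyl on a sulfonamide nitrogen gives a 5.2-fold lower number from compound 3 to compound 4 (0.72 log units; beyond the scatter) and sets compound 3 apart from all three other compounds. Going by these compounds alone, the new group cannot be told from the two earlier ones, with a 1.5-fold lower number from compound 2 to compound 4 (0.18 log units; within the scatter) and a 1.7-fold lower number from compound 1 to compound 4 (0.24 log units; within the scatter) both falling inside the usual scatter, so 3,4-dimethylphenyl, 3-chlorophenyl and 4-chloro-2-methylphenyl form one group on this read-out, while compound 3, the only compound carrying fluoro, stands alone. Chloro alone does not mark the difference, since compound 1, compound 3 and compound 4 all carry it, and no measurement given here explains why these aryl groups behave as they do.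

With a single fluoro compound, the compounds shown leave open whether fluoro itself goes with the weaker inhibition of growth or only this particular 3-chloro-5-fluorophenyl group does. They also leave open how this position would answer to an amine or a carboxylic acid on the aromatic ring, or to a cyclohexyl group in place of the aryl group on the sulfonamide nitrogen.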